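Aryl Variation on the Ring Nitrogen: Compound 3 to 4

The compounds below may be only part of what the source reports. "The series", "measured", "known", "first", "only" and "open" are said of these compounds alone.

Compound 3 `CC(C)(C)C1=NN(c2cccc(F)c2)C(c2ccc(O)cc2)C1` gives 98.1% in an assay on isolated protein for inhibition of protein kinase C zeta type (Homo sapiens), with a stated time of 4 min, tested at 62.5 uM (a higher number here means more inhibition at the concentration tested (going by the name of the read-out), a lower number less inhibition), the highest of the three numbers measured. Compound 1 `CC(C)(C)C1=NN(c2ccc(C(F)(F)F)cc2)C(c2ccc(O)cc2)C1` is nearest, giving 94.2%, which sits within the scatter of compound 3. Compound 2 `CC(C)c1ccc(N2N=C(C(C)(C)C)CC2c2ccc(O)cc2)cc1` is furthest, giving 54.9%, a gap beyond the scatter.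

Compound 4 `CC(C)(C)C1=NN(c2c(Cl)cccc2Cl)C(c2ccc(O)cc2)C1` is not yet measured. Its change from compound 3 is 2,6-dichlorophenyl in place of 3-fluorophenyl on an amine nitrogen in a ring.

For the measured compounds named here, the only measured step on this aromatic ring is a number 39.3 percentage points lower from compound 1 to compound 2 (beyond the scatter), a large fall when isopropyl replaces trifluoromethyl. Going by the values given here, no step involves chlorine or a 2,6-substitution pattern, so that step bears only loosely. Compound 1 and compound 3 both carry a single small substituent and both read high; compound 2, with the larger group, reads low. Compound 4 carries two substituents, and a downward step is expected from compound 3 to compound 4, of size a number 18.1 percentage points lower from compound 3 to compound 4 (beyond the scatter), though it may stay within the scatter. Compound 4 is estimated at 80%, with a range from 50% to 98%.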

Compound 4, a percentage reported as inhibition, at one concentration (the size of the read-out at that concentration, not a potency): 65.5%
Compound 4: middle estimate off by 14.5 percentage points, on the high side, and the stated range covers the measured number.
By their numbers in this assay, from the lowest: compound 2; then compound 4; then compounds 1 and 3 (each within the scatter of the next).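

Putting 2,6-dichlorophenyl in place of 3-fluorophenyl on the amine nitrogen in the ring gives a number 32.6 percentage points lower from compound 3 to compound 4 (beyond the scatter) in this assay. This is a second large fall at this position, alongside a number 39.3 percentage points lower from compound 1 to compound 2 (beyond the scatter), so a high reading is not shared by every aryl group here, and a step of this size is not confined to the change from trifluoromethyl to isopropyl. No measurement at hand accounts for the fall from compound 3 to compound 4.

The compounds shown leave open whether the fall follows from having two chlorines or from where they stand, and a phenyl carrying a single chlorine would help separate the two. As far as these compounds go, how an amine or a carboxylic acid on this phenyl would read in this assay also remains open.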